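Iodo for fluoro on the benzyl ring of compound 2

This account rests on a few compounds, and the source may have more. Where it says the series, first, only, none or still open, it means among the compounds named here.

Of the compounds shown here, two sharing one core have been measured in a functional assay on 1321-N1 cells for agonist activity at P2Y purinoceptor 2 (Homo sapiens), read by scintillation counting and inositol phosphate accumulation; a higher number here means that more compound is needed for the effect, a lower number that less compound is needed. Compound 1 `O=c1[nH]/c(=N\OCCOc2ccccc2)ccn1[C@@H]1O[C@H](COP(=O)(O)OP(=O)(O)OP(=O)(O)O)[C@@H](O)[C@H]1O` gives 3400 nM in this assay, and compound 2 `O=c1[nH]/c(=N\OCCCc2cccc(F)c2)ccn1[C@@H]1O[C@H](COP(=O)(O)OP(=O)(O)OP(=O)(O)O)[C@@H](O)[C@H]1O` gives 190 nM. Going by the values given here, the single measured step, an 18-fold lower number from compound 1 to compound 2 (1.25 log units; beyond the scatter), is large, so compound 2 stands at the lowest number of the two, with compound 1 as its only neighbour and that neighbour far away. Compound 3 `O=c1[nH]/c(=N\OCCCc2cccc(I)c2)ccn1[C@@H]1O[C@H](COP(=O)(O)OP(=O)(O)OP(=O)(O)O)[C@@H](O)[C@H]1O` differs from compound 2 by iodo in place of fluoro on an aromatic carbon. Among the compounds with values here, no measured step exchanges one halogen for another: the step from compound 1 to compound 2 altered the chain and the ring substituent together and does not bear directly on this exchange. With no measured guide, the step of a 1.3-fold lower number from compound 2 to compound 3 (0.10 log units; within the scatter) is expected to lie within the scatter or, at most, to be modest. Compound 3 is therefore estimated at 150 nM in this assay, with a range from 40 nM to 600 nM.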

Compound 3, half-maximal effective concentration: 325 nM
For compound 3 the middle estimate is 2.2-fold (0.34 log units) below the measured one; low and high end bracket the measured number.
By their numbers in this assay, from the lowest: compounds 2 and 3 (each within the scatter of the next); then compound 1.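

In this assay, iodo in place of fluoro on the aromatic carbon gives a 1.7-fold higher number from compound 2 to compound 3 (0.23 log units; within the scatter) and so stays within the scatter: at this place on the ring, the two halogens cannot be told apart. The large change from the phenoxy compound also holds with iodo, at a 10-fold lower number from compound 1 to compound 3 (1.02 log units; beyond the scatter), so it does not depend on fluoro alone. Nothing available accounts for either result.

The compounds shown leave open whether this ring carbon would tolerate a group other than a halogen, such as methoxy, an amine or a carboxylic acid. They also leave open how a plain benzyl without any halogen, or a longer chain carrying 3-iodophenyl, would compare with compound 2 and compound 3.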